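The source may hold more compounds than are shown below. What is called first, only, known or untested is meant among the compounds shown, and "the series" means these compounds.

Compound 3, `CCCN(CCC)S(=O)(=O)c1ccc(NC(=O)C(C)(O)C(F)(F)F)cc1`, is the reference point of this step. In an assay on a protein complex (Cavia porcellus) with sulfonylurea receptors; K-ATP channels (Homo sapiens) as the target (on this read-out higher numbers stand for weaker inhibition and lower numbers for stronger inhibition), compound 3 gives 6440 nM, the lowest of the two numbers obtained. Its nearest neighbour is compound 1, `Cn1nnnc1-c1ccc(NC(=O)C(C)(O)C(F)(F)F)cc1`, which in this assay gives 30900 nM. Compound 2, `CC(O)(C(=O)Nc1ccc(S(=O)(=O)N2CCNCC2)cc1)C(F)(F)F`, gives only a limit in this assay, > 30000 nM; this is the limit of > 30000 nM in this assay, at which 1 of the 3 values shown sits. Within the data shown here, the one measured change at the sulfonyl sulfur is an at least 4.6-fold lower number from compound 2 to compound 3 (0.66 log units; beyond the scatter).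

Compound 4 is `CN(C)S(=O)(=O)c1ccc(NC(=O)C(C)(O)C(F)(F)F)cc1`. It differs from compound 3 in one place: dimethylamino in place of dipropylamino on a sulfonyl sulfur. Among the measured compounds shown here, only the step from compound 2 to compound 3 bears on this change, and it ran in the opposite sense on the same sulfonyl sulfur, with dipropylamino entering and the number falling. Shortening the chains to dimethylamino is therefore expected to send the number of compound 4 back upward in this assay, though not necessarily by the full amount of that earlier step. The step from compound 3 to compound 4 is estimated at a 2.3-fold higher number from compound 3 to compound 4 (0.37 log units; beyond the scatter). Compound 4 is thus expected to give about 15000 nM, with a likely range from 5000 nM to 40000 nM.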

Compound 4, half-maximal inhibitory concentration: 480 nM
Compound 4: the middle estimate sits 31-fold (1.49 log units) above what was measured; the whole stated range lies above it.
By their numbers in this assay, from the lowest: compound 4; then compound 3; then compound 1.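

In this assay, among these compounds, the sulfonyl sulfur proves far more responsive than the earlier compounds suggested: dimethylamino in place of dipropylamino gives a 13-fold lower number from compound 3 to compound 4 (1.13 log units; beyond the scatter), so the fall seen earlier with an at least 4.6-fold lower number from compound 2 to compound 3 (0.66 log units; beyond the scatter) did not mean that longer chains on this sulfur lower the number. Dimethylamino in place of piperazin-1-yl on the sulfonyl sulfur gives an at least 62-fold lower number from compound 2 to compound 4 (1.79 log units; beyond the scatter), and dimethylsulfamoyl in place of 1-methyl-1H-tetrazol-5-yl on an aromatic carbon gives a 64-fold lower number from compound 1 to compound 4 (1.81 log units; beyond the scatter), which makes dimethylamino the group with the lowest number among those shown. The first of these two steps has an open end, as compound 2 gives only a limit: the limit of > 30000 nM in this assay, at which 1 of the 4 values shown sits.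

Going by these compounds, whether the number would fall further with a plain amino group on the sulfur, or lie between those of compound 3 and compound 4 with diethylamino, stays open. On these data alone, it is also open whether a cyclic amine such as pyrrolidin-1-yl or morpholin-4-yl would follow dimethylamino or piperazin-1-yl on this sulfur.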